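Dropping One Trifluoromethyl Group from a Urea Tail

The source may report more compounds than this note shows. Statements on the series, on what has been measured and on what is new or still open speak of the compounds shown alone.

Measured so far:
- compound 1 `COc1cc(Cl)cc(-c2nn(-c3cccc(NC(=O)c4ccc(Cl)c(Cl)c4)c3)cc2-c2ccncc2)c1`: 77.8%
- compound 2 `O=C(Nc1cccc(-n2cc(-c3ccncc3)c(-c3cc(O)cc(Cl)c3)n2)c1)Nc1ccc(Cl)c(Cl)c1`: 0.57%
- compound 3 `COc1cc(Cl)cc(-c2nn(-c3cccc(NC(=O)Nc4cc(C(F)(F)F)cc(C(F)(F)F)c4)c3)cc2-c2ccncc2)c1`: 9.5%

All three numbers come from a functional assay on HCC 2998 cells (Homo sapiens) for inhibition, read by sulforhodamine B assay, with a stated time of 48 h, tested at 10 uM; on this read-out lower numbers stand for a stronger effect and higher numbers for a weaker effect at the one concentration tested. Compound 3 sits second highest of the three; its value lies within the scatter of compound 2, while compound 1 stands far higher, beyond the scatter. Compound 4 `COc1cc(Cl)cc(-c2nn(-c3cccc(NC(=O)Nc4cccc(C(F)(F)F)c4)c3)cc2-c2ccncc2)c1` is not yet measured. It differs from compound 3 in one place: hydrogen in place of trifluoromethyl on an aromatic carbon. Going by the values given here, since no directly measured pair shows what one such change does, the expectation rests only on the three values shown. A modest loss of effect is expected, so the step of a number 15.5 percentage points higher from compound 3 to compound 4 (beyond the scatter) is estimated to be upward but small. Compound 4 is therefore expected to give about 25%, within 5% to 60%.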

Compound 4, a percentage reported as activity, at one concentration (the size of the read-out at that concentration, not a potency): 19%
Compound 4: middle estimate off by 6 percentage points, on the high side; the range from low to high includes it.
By their numbers in this assay, from the lowest: compounds 2, 3 and 4 (each within the scatter of the next, the first and the last beyond it); then compound 1.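

In this assay, the change gives a number 9.5 percentage points higher from compound 3 to compound 4 (within the scatter), so the effect at the one concentration tested does not depend on keeping this second trifluoromethyl group. The other step, a number 58.8 percentage points lower from compound 1 to compound 4 (beyond the scatter), is far larger and shows that replacing 3,4-dichlorophenyl on the carbonyl carbon with (3-(trifluoromethyl)phenyl)amino matters much more than the loss of trifluoromethyl. No measured evidence here explains either step. Still open, from the compounds shown here alone, is whether a nitrile or a methoxy group on this aromatic carbon would hold the effect, and whether the remaining trifluoromethyl group can also be replaced by hydrogen.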